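Enlarging the acetyl group of compound 3

The source may report more compounds than this note shows. Statements on the series, on what has been measured and on what is new or still open speak of the compounds shown alone.

In a functional assay on Hep 3B2 cells (Homo sapiens) for cytotoxicity, read by MTT assay (a lower number here means a stronger inhibitor, a higher number a weaker inhibitor), compound 3 `CC(=O)N1CCC(C[C@@H](c2nc3ccc(C)cc3n2C)N2C(=O)CN(c3ccc(Oc4ccccc4)cc3)C2=O)CC1` gives 17200 nM, within the scatter of compound 1 `Cc1ccc2nc([C@H](CC3CCNCC3)N3C(=O)CN(c4ccc(Oc5ccccc5)cc4)C3=O)n(C)c2c1` at 16700 nM, while compound 2 `Cc1ccc2nc([C@H](CC3CCN(CC(C)C)CC3)N3C(=O)CN(c4ccc(Oc5ccccc5)cc4)C3=O)n(C)c2c1` gives 6900 nM. Compound 4 `Cc1ccc2nc([C@H](CC3CCN(C(=O)C(C)C)CC3)N3C(=O)CN(c4ccc(Oc5ccccc5)cc4)C3=O)n(C)c2c1` differs from compound 3 by isopropyl in place of methyl on a carbonyl carbon. Within the data shown here, no measured step changes that group directly. The nearest evidence comes from changes on the ring nitrogen, and these are small: a 2.4-fold lower number from compound 1 to compound 2 (0.38 log units; beyond the scatter), a 1.0-fold higher number from compound 1 to compound 3 (0.01 log units; within the scatter) and a 2.5-fold higher number from compound 2 to compound 3 (0.40 log units; beyond the scatter). Only a small shift therefore seems likely, with no change beyond the scatter expected. The expected step is a 1.3-fold lower number from compound 3 to compound 4 (0.11 log units; within the scatter). For compound 4, the estimated value is 13500 nM, with an expected range of 6500 nM to 25000 nM.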

Compound 4, half-maximal inhibitory concentration: > 100000 nM
Compound 4 gave a limit, no number (the forecaster's own chance of this, stated with the estimate: 10%); middle value at least 7.4-fold (0.86 log units) away from the limit.
By their numbers in this assay, from the lowest: compound 2; then compounds 1 and 3 (each within the scatter of the next). At a limit, above all of these: compound 4.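

In this assay, compound 4 gives only a limit, not a number: the limit of > 100000 nM in this assay, at which 1 of the 4 values shown sits.

The carbonyl carbon is not indifferent to change: isopropyl in place of methyl gives an at least 5.8-fold higher number from compound 3 to compound 4 (0.76 log units; beyond the scatter), although acetyl on the ring nitrogen gave only a 1.0-fold higher number from compound 1 to compound 3 (0.01 log units; within the scatter). Isopropylcarbonyl on that nitrogen also gives an at least 5.9-fold higher number from compound 1 to compound 4 (0.77 log units; beyond the scatter), and in place of isobutyl it gives an at least 14-fold higher number from compound 2 to compound 4 (1.16 log units; beyond the scatter).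

Going by these compounds, it remains open whether an unbranched propionyl group or a ring-bearing benzoyl group on the same nitrogen would behave like acetyl or like isopropylcarbonyl. A methanesulfonyl group there is equally untested among the compounds shown.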